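The compounds below may be only part of what the source reports. "The series", "measured", "known", "first", "only" and "open" are said of these compounds alone.

Compound 1 `CS(=O)(=O)c1ccccc1C(=O)N1CCC(N(C2CC2)S(=O)(=O)c2cccc(C(F)(F)F)c2)CC1` is the reference point of the series. In an assay on HEK293 cells for inhibition of Voltage-dependent N-type calcium channel subunit alpha-1B (Homo sapiens), read by FLIPR and calcium flux, in the presence of a further agent that is not named here (a lower number here means a stronger inhibitor, a higher number a weaker inhibitor), compound 1 gives 660 nM, the second highest of the three numbers measured. For the measured compounds named here, its nearest neighbour is compound 2 `CS(=O)(=O)c1ccc(F)cc1C(=O)N1CCC(N(C2CC2)S(=O)(=O)c2cccc(C(F)(F)F)c2)CC1`, which in this assay gives 560 nM; the step of a 1.2-fold lower number from compound 1 to compound 2 (0.07 log units; within the scatter) is the only comparison that stays within the scatter. Compound 3 `CS(=O)(=O)c1ccc(F)cc1C(=O)N1CCC(N(C2CC2)S(=O)(=O)c2cc(C(F)(F)F)ccc2F)CC1` lies furthest away with 2500 nM in this assay, reached through a 4.5-fold higher number from compound 2 to compound 3 (0.65 log units; beyond the scatter).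

Compound 4 `O=C(c1cccc(OC(F)(F)F)c1)N1CCC(N(C2CC2)S(=O)(=O)c2cccc(C(F)(F)F)c2)CC1` differs from compound 1 by 3-(trifluoromethoxy)phenyl in place of 2-(methylsulfonyl)phenyl on a carbonyl carbon. Neither measured step touches the aryl on the carbonyl carbon: both are single fluoro-for-hydrogen changes, one on the aryl of the carbonyl and one on the aryl of the sulfonyl. Going by the values given here, no measured step therefore bears directly on the change to compound 4, and the expectation for this assay rests on the absence of precedent rather than on a trend. A modest shift in either direction is the most that can be expected, and the estimate for compound 4 is set close to compound 1 with a wide range. Compound 4 is expected to give 1000 nM in this assay, between 300 nM and 4000 nM, which corresponds to an expected step of a 1.5-fold higher number from compound 1 to compound 4 (0.18 log units; within the scatter).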

Compound 4, half-maximal inhibitory concentration: 370 nM
Estimate against measurement, compound 4: 2.7-fold (0.43 log units) above, within the range that was stated.
By their numbers in this assay, from the lowest: compounds 4, 2 and 1 (each within the scatter of the next); then compound 3.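

On the carbonyl carbon, the whole aryl group can be exchanged without a change beyond the scatter: in this assay, 3-(trifluoromethoxy)phenyl in place of 2-(methylsulfonyl)phenyl gives a 1.8-fold lower number from compound 1 to compound 4 (0.25 log units; within the scatter), and in place of 5-fluoro-2-(methylsulfonyl)phenyl it gives a 1.5-fold lower number from compound 2 to compound 4 (0.18 log units; within the scatter). The earlier compounds shown here showed only fluoro-for-hydrogen changes, whereas compound 4 shows that, with the rest of the core of compound 1 kept, the methylsulfonyl group is not required at this position to stay within the scatter of compound 1. Nothing measured here accounts for this result.

As far as these compounds go, how a carboxylic acid or a primary amine in place of the trifluoromethoxy group would read in this assay remains open. Also open, from the compounds shown here alone, is whether the step from compound 2 to compound 3 carries over when 3-(trifluoromethoxy)phenyl sits on the carbonyl carbon.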